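Cytotoxicity series: swapping the halogenated aryl arm

The source may report more compounds than this note shows. Statements on the series, on what has been measured and on what is new or still open speak of the compounds shown alone.

Measured compounds:
compound 1 `COc1cc(/C=C2\CN(C)C/C(=C\c3ccc(Br)cc3)C2=O)cc(OC)c1OC`, 6800 nM
compound 2 `COc1cc(/C=C2\CN(C)C/C(=C\c3ccc(Cl)cc3Cl)C2=O)cc(OC)c1OC`, 8800 nM
compound 3 `CN1C/C(=C\c2ccc(Br)cc2)C(=O)/C(=C/c2ccc(C#N)cc2)C1`, 4840 nM

All three were run in a functional assay on HepG2 cells (Homo sapiens) for cytotoxicity, read by MTT assay, with a stated time of 24 h; on this read-out lower numbers stand for stronger inhibition and higher numbers for weaker inhibition. Compound 1 and compound 2 share one core; compound 3 carries a different core, and the difference between the two cores is not broken down here. The values of compound 1, compound 2 and compound 3 all lie within the scatter of one another, so none of them can be set apart as stronger or weaker on this read-out.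

Within the first core, compound 2 differs from compound 1 by one change: 2,4-dichlorophenyl in place of 4-bromophenyl on a double-bonded chain carbon bound to a double-bonded ring carbon. The step it made was a 1.3-fold higher number from compound 1 to compound 2 (0.11 log units; within the scatter), a shift that does not leave the scatter.

The same change is now to be made on the second core. Compound 4 `CN1C/C(=C\c2ccc(C#N)cc2)C(=O)/C(=C/c2ccc(Cl)cc2Cl)C1` is not yet measured; it differs from compound 3 by 2,4-dichlorophenyl in place of 4-bromophenyl on a double-bonded chain carbon bound to a double-bonded ring carbon. For the measured compounds named here, the only evidence on this change is the step from compound 1 to compound 2, which was small; the two cores are not matched in any other pair, so it is not known whether the second core responds in the same way.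

On that basis compound 4 is expected to come out close to compound 3, with a step of about a 1.3-fold higher number from compound 3 to compound 4 (0.11 log units; within the scatter), resting on the earlier step of a 1.3-fold higher number from compound 1 to compound 2 (0.11 log units; within the scatter). The estimate for compound 4 in this assay is 6300 nM, with a likely range from 3000 nM to 13000 nM.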

Compound 4, half-maximal inhibitory concentration: 6250 nM
For compound 4 the middle estimate is 1.0-fold (0.00 log units) above the measured one; low and high end bracket the measured number.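

In this assay, placing 2,4-dichlorophenyl in place of 4-bromophenyl on the second core gave a 1.3-fold higher number from compound 3 to compound 4 (0.11 log units; within the scatter), so this step stays inside the scatter, as the earlier one did. Set side by side, the two steps do not differ, and the change carries from the first core to the second without any detectable departure: the same change on two cores in this assay, a 1.3-fold higher number (0.11 log units; within the scatter) from compound 1 to compound 2 and a 1.3-fold higher number (0.11 log units; within the scatter) from compound 3 to compound 4, 1.0-fold (0.00 log units) apart, within the scatter of two such steps This agreement rests on only two matched pairs, and as neither step leaves the scatter, the pairs show that the two aryl groups cannot be told apart on this read-out in either core, not that the change has a real effect of a shared size, and they say nothing about how it would behave on any further core.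

The compounds shown contain only halogen and nitrile substituents on the aryl arms, so it remains open whether an arm bearing an amine or a carboxylic acid would give a step beyond the scatter on either core. All four compounds also share the same methyl group on the core, which leaves open what a longer chain in its place would do to the number in this assay.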